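Bromine position in the chalcone series, compound 2 to 4

The source may hold more compounds than are shown below. What is called first, only, known or untested is meant among the compounds shown, and "the series" means these compounds.

Compound 1 `CCOc1ccccc1OCCSC(=S)N[C@H]1CCOC1=O`, compound 2 `O=C(COc1ccc(C(=O)/C=C/c2ccccc2Br)cc1)N[C@H]1CCOC1=O` and compound 3 `CC(C)c1ccc(NCC(=O)N[C@H]2CCOC2=O)cc1` have been tested in a functional assay on MGC-803 cells (Homo sapiens) for antiproliferative activity, read by MTT assay, with a stated time of 72 h; a lower number here means a stronger inhibitor, a higher number a weaker inhibitor. Compound 1 reaches only the limit > 64000 nM. Compound 3 likewise stops at the limit > 64000 nM. Compound 2 gives 12200 nM and is the only one of the three to return a number. The other two values sit at the limit of > 64000 nM in this assay, at which 2 of the 3 values shown sit. Compound 4 `O=C(COc1ccc(C(=O)/C=C/c2ccc(Br)cc2)cc1)N[C@H]1CCOC1=O` is not yet measured. It differs from compound 2 by 4-bromophenyl in place of 2-bromophenyl on a double-bonded chain carbon bound to a double-bonded chain carbon. Going by the values given here, no step between measured compounds is available to set the size of this change, so the expected shift from compound 2 to compound 4 is a 1.4-fold lower number from compound 2 to compound 4 (0.13 log units; within the scatter), taken as within the scatter. Compound 4 is expected to give about 9000 nM in this assay, with a range from 3000 nM to 30000 nM.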

Compound 4, half-maximal inhibitory concentration: 51000 nM
Estimate against measurement, compound 4: 5.7-fold (0.75 log units) below, outside the stated range (above it).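

In this assay, going by these compounds alone, 4-bromophenyl in place of 2-bromophenyl gives the first readable step, and it is not neutral: a 4.2-fold higher number from compound 2 to compound 4 (0.62 log units; beyond the scatter). With the same atoms joined differently, the place of the bromine on the phenyl alone moves the number beyond the scatter, and 2-bromophenyl gives the lower number of the two. Readable values remain scarce: the limit of > 64000 nM in this assay, at which 2 of the 4 values shown sit.

Going by these compounds, whether bromine itself is needed stays open, as neither an unsubstituted phenyl nor a chlorine in its place stands beside compound 2. Also open, on these data alone, is how far a carboxylic acid or an amine on that phenyl would move the number.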